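Swapping the aryl group on a weak growth inhibitor

This account rests on a few compounds, and the source may have more. Where it says the series, first, only, none or still open, it means among the compounds named here.

Values so far in a functional assay on ACHN cells (Homo sapiens) (on this read-out lower numbers stand for stronger inhibition of growth and higher numbers for weaker inhibition of growth), for two compounds
- Compound 1 `N#Cc1ccc(/C=C/S(=O)(=O)Cc2ccc(Nc3ncnc4ccccc34)cc2)cc1` gives > 100000 nM as a limit, not a number
- Compound 2 `O=S(=O)(/C=C/c1ccc(F)cc1Cl)Cc1ccc(Nc2ncnc3ccccc23)cc1` gives 73000 nM as a measured number

Going by the values given here, compound 2 holds the only true number in this assay so far. Compound 1 stands at the limit of > 100000 nM in this assay, at which 1 of the 2 values shown sits, and offers no exact number for comparison. Among the compounds with values here, only one measured step exists at this place, and it reads an at least 1.3-fold lower number from compound 1 to compound 2 (0.13 log units; that floor lies within the scatter) as its whole result. This step therefore shows no clear effect of exchanging the aryl group.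

Compound 3 `O=S(=O)(/C=C/c1ccc(C(F)(F)F)cc1F)Cc1ccc(Nc2ncnc3ccccc23)cc1` has not yet been measured. Its change from compound 2 is 2-fluoro-4-(trifluoromethyl)phenyl in place of 2-chloro-4-fluorophenyl on a double-bonded chain carbon bound to a double-bonded chain carbon and it again falls on the same chain carbon. Within the data shown here, the only guide is that single step, so a shift beyond the scatter is not expected in either direction. The expected result is a 1.2-fold lower number from compound 2 to compound 3 (0.09 log units; within the scatter) and so no real change. For compound 3 the estimated value is 60000 nM with an expected range from 25000 nM to 100000 nM in this measurement. A reading that gives only a limit would be no surprise.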

Compound 3, concentration for 50% growth inhibition: 100000 nM
Beside the measured number, compound 3's estimate is 1.7-fold (0.22 log units) below it, and the stated range covers the measured number.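

In this assay, 2-fluoro-4-(trifluoromethyl)phenyl in place of 2-chloro-4-fluorophenyl on a double-bonded chain carbon bound to a double-bonded chain carbon gives a 1.4-fold higher number from compound 2 to compound 3 (0.14 log units; within the scatter). Going by these compounds alone, this is the first step at this position that joins two true numbers, and it shows that going from 2-chloro-4-fluorophenyl, with 8 heavy atoms, to 2-fluoro-4-(trifluoromethyl)phenyl, with 11 heavy atoms and no chlorine, does not shift growth inhibition beyond the scatter, so for this pair the position tolerates a change in both the size and the halogens of the aryl group without a readable gain or loss. With 2-fluoro-4-(trifluoromethyl)phenyl in place of 4-cyanophenyl at the same place, the data give a number no higher from compound 1 to compound 3 (the limit leaves the size open). This step cannot be read, since compound 1 gives only a limit: the limit of > 100000 nM in this assay, at which 1 of the 3 values shown sits.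

From the compounds shown here alone, compound 2 and compound 3 both carry halogens on a six-membered aromatic ring of carbon only, so it remains open whether a quite different group on this chain carbon, such as a phenyl ring bearing an amine or a carboxylic acid, would lower the number beyond the scatter. Going by these compounds, it also remains open whether a change elsewhere, in the sulfonyl link or the shared core, would matter more than any exchange at this position.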